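The compounds below may be only part of what the source reports. "The series", "measured", "known", "first", "only" and "open" are said of these compounds alone.

Compound 3 `Cc1nc(N)c2c(-c3cc4ccccc4o3)cn([C@@H]3O[C@H](CO)[C@@H](O)[C@H]3O)c2n1` sits at the edge of what the measurement can report. In a functional assay on HepG2 cells (Homo sapiens) for antiproliferative activity, read by XTT assay, with a stated time of 72 h (on this read-out lower numbers stand for stronger inhibition and higher numbers for weaker inhibition), compound 3 gives > 20000 nM, which is a limit of the assay rather than a number. Two related compounds share this position. Compound 1 `Nc1nc(N)c2c(-c3cc4ccccc4o3)cn([C@@H]3O[C@H](CO)[C@@H](O)[C@H]3O)c2n1` gives in this assay > 20000 nM, again a limit. Compound 2 `O=c1[nH]cnc2c1c(-c1cccs1)cn2[C@@H]1O[C@H](CO)[C@@H](O)[C@H]1O` gives in this assay > 20000 nM, also a limit. For the measured compounds named here, the one change between measured compounds, methyl in place of amino on an aromatic carbon, reads as a step that the two limits leave unreadable from compound 1 to compound 3, so its size cannot be told, because of the limit of > 20000 nM in this assay, at which 3 of the 3 values shown sit.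

Compound 4 `Cc1nc(N)c2c(-c3ccccc3)cn([C@@H]3O[C@H](CO)[C@@H](O)[C@H]3O)c2n1` is the untested partner of compound 3. The change is phenyl in place of 1-benzofuran-2-yl on an aromatic carbon. Going by the values given here, no measured step touches this change, so the evidence offers only the common limit at which every measured compound rests. Compound 4 is therefore expected to remain near that limit, estimated at 30000 nM with a range from 10000 nM to 100000 nM. The estimated step that the limit leaves unreadable from compound 3 to compound 4 is expected to lie within the usual scatter.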

Compound 4, half-maximal inhibitory concentration: > 20000 nM
Compound 4: only a limit was reported; the forecaster's own chance of this, stated with the estimate: 75%; the middle value is on the limit's open side.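

No size can be read for the step from compound 3 to compound 4, because both compounds rest at the same limit rather than at a number: the limit of > 20000 nM in this assay, at which 4 of the 4 values shown sit. The compounds shown leave open which change to the shared core, if any, would give a measurable value.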